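Removing bromine from a sulfanyl-linked aryl ring

This account rests on a few compounds, and the source may have more. Where it says the series, first, only, none or still open, it means among the compounds named here.

Measured compounds:
- compound 1, `CC(O)(CS(=O)(=O)c1ccc(Br)cc1)c1nc(-c2ccccc2)no1`: in a functional assay on DU-145 cells (Homo sapiens) for cytotoxicity, read by MTT assay (a higher number here means a weaker inhibitor, a lower number a stronger inhibitor), compound 1 gives > 100000 nM
- compound 2, `CC(O)(CS(=O)(=O)c1ccccc1)c1nc(-c2ccccc2)no1`: compound 2 gives > 100000 nM
- compound 3, `CC(O)(CSc1ccc(Br)cc1)c1nc(-c2ccc([N+](=O)[O-])c(C(F)(F)F)c2)no1`: compound 3 gives 1600 nM

The value of compound 1 is a limit of the assay, not a number. The value of compound 2 is likewise a limit. Among the measured compounds shown here, because of this, the step that the two limits leave unreadable from compound 1 to compound 2 cannot be read; the two measurements sit at the limit of > 100000 nM in this assay, at which 2 of the 3 values shown sit, and show only that neither compound reached a measurable concentration. Compound 3 alone gives a real number.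

Compound 1 and compound 3 differ in more than one place, and the difference between the two cores is not broken down here. Compound 4, `CC(O)(CSc1ccccc1)c1nc(-c2ccc([N+](=O)[O-])c(C(F)(F)F)c2)no1`, has not yet been measured. It comes from compound 3 by hydrogen in place of bromo on an aromatic carbon. The same change, (hydrogen in place of bromo on an aromatic carbon), carries compound 1 into compound 2, and the two place descriptions match word for word, so it is the same change made twice.

For the measured compounds named here, since the first instance of the change is hidden behind two limits, it carries no information about how far the second instance should move. The expectation for compound 4 therefore rests on compound 3 alone, whose 1600 nM anchors it, together with the smallness of the change: a single bromine atom leaves. In this assay compound 4 is expected to stay near compound 3, with an estimated step of a 1.6-fold higher number from compound 3 to compound 4 (0.19 log units; within the scatter). The estimated value for compound 4 is 2500 nM, expected to lie between 800 nM and 8000 nM.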

Compound 4, half-maximal inhibitory concentration: 3000 nM
For compound 4 the middle estimate is 1.2-fold (0.08 log units) below the measured one; the measured number falls inside the stated range.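

In this assay, replacing the bromo group with hydrogen on the core that gives real numbers produces a 1.9-fold higher number from compound 3 to compound 4 (0.27 log units; within the scatter), so on this core the change from 4-bromophenyl to phenyl makes no difference that can be told apart from ordinary repeat-to-repeat variation. The same swap on the other core cannot be read, because compound 1 and compound 2 each report a limit of the assay and not a number: the limit of > 100000 nM in this assay, at which 2 of the 4 values shown sit. The series therefore offers just one readable instance of this change, which shows that it is tolerated on that one core but does not show that it would behave the same way on another core.

From the compounds shown here alone, only bromo and hydrogen appear at this place on the ring, so it remains open how an amine or a carboxylic acid there would read in this assay. Compound 1 and compound 3 also differ in more than one place, which leaves open how much each of those differences contributes to the gap between a limit and a real number.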